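A few compounds are considered here, and "the series" means these few. Any claim that something is new, unique, unknown or untested is made for them only; others in the source may bear on it.

Measured so far in a physicochemical assay for lipophilicity; a higher number here means a more lipophilic compound, a lower number a more polar compound:
- compound 1, `Cc1ccc(NC(=O)CC(CCN(C)C)c2nnc(CCCC(C)C)n2C2CC2)c(C)c1`: compound 1 gives 3.3
- compound 2, `CC(=O)NCCC(CC(=O)Nc1ccc(C)cc1C)c1nnc(CCCC(C)C)n1C1CC1`: compound 2 gives 3.5
- compound 3, `Cc1ccc(NC(=O)C[C@H](CCC(=O)O)c2noc(-c3cc(CC(C)C)on3)c2C2CC2)c(Cl)c1`: compound 3 gives 3.9

Compound 3 stands highest of the three numbers in this assay. Its nearest neighbour is compound 2, whose value lies lower by more than the scatter; compound 1 lies furthest, also beyond the scatter. Going by the values given here, the only step recorded between two measured compounds is a number 0.20 log units higher from compound 1 to compound 2 (within the scatter), which exchanges acetamido for dimethylamino on a saturated chain carbon and therefore says nothing direct about the change now considered.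

Compound 4, `Cc1ccc(NC(=O)C[C@H](CCC(=O)O)c2noc(-c3cc(CC(C)(C)C)on3)c2C2CC2)c(Cl)c1`, differs from compound 3 by methyl in place of hydrogen on a saturated chain carbon bound to three saturated chain carbons. Among the compounds with values here, no measured step covers a methyl in place of hydrogen, so the expectation rests on the change itself rather than on a precedent within these compounds. Starting from compound 3, a modest rise in this assay is expected, a number 0.40 log units higher from compound 3 to compound 4 (beyond the scatter). Compound 4 is accordingly estimated at 4.3, with a range from 4 to 4.7.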

Compound 4, distribution coefficient: 4.2
Compound 4: middle estimate off by 0.10 log units, on the high side, within the range that was stated.
By their numbers in this assay, from the lowest: compounds 1 and 2 (each within the scatter of the next); then compounds 3 and 4 (each within the scatter of the next).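

In this assay, going by these compounds alone, the change from isobutyl to neopentyl gives a number 0.30 log units higher from compound 3 to compound 4 (within the scatter) and is the only reading of methyl in place of hydrogen. At this saturated chain carbon bound to three saturated chain carbons, the added methyl leaves compound 3 and compound 4 within the scatter of each other, so this one pair does not separate the change from repeat variation. No measured information bears on what lies behind this step.

As far as these compounds go, whether a hydroxyl, a primary amine or a longer chain on this carbon would give a step beyond the scatter remains open. Also open, from the compounds shown here alone, is whether methyl in place of hydrogen would read the same way elsewhere on the shared core or in another pair.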